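Replacing (3-chlorophenyl)amino with ethoxy on a carbonyl carbon

The compounds below may be only part of what the source reports. "The series", "measured", "known", "first", "only" and "open" are said of these compounds alone.

- compound 1 `CC(C)NC(=S)NC1CC(C)(C)Oc2ccc(Cl)cc21` gives 57000 nM
- compound 2 `CCNC(=S)NC1CC(C)(C)Oc2ccc(Cl)cc21` gives 96000 nM
- compound 3 `CC1(C)CC(NC(=O)Nc2cccc(Cl)c2)c2cc(Cl)ccc2O1` gives 21000 nM

All three values come from a functional assay on U-373MG ATCC cells (Homo sapiens) for inhibition, read by MTT assay, with a stated time of 72 h (on this read-out higher numbers stand for weaker inhibition and lower numbers for stronger inhibition), where compound 3 has the lowest number of the three, clearly apart from the other two. Compound 4 `CCOC(=O)NC1CC(C)(C)Oc2ccc(Cl)cc21` has not yet been measured. The change from compound 3 to compound 4 is ethoxy in place of (3-chlorophenyl)amino on a carbonyl carbon, so the aromatic ring leaves along with the amino group.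

For the measured compounds named here, no measured step covers this swap directly. Going by the values given here, the only step available, a 1.7-fold higher number from compound 1 to compound 2 (0.23 log units; within the scatter), stays within the scatter and concerns hydrogen in place of methyl on a saturated chain carbon, so it offers little guidance on the size of this change. The values give a rough guide instead. Compound 1 gives 57000 nM and compound 2 gives 96000 nM without the (3-chlorophenyl)amino, and both numbers are higher than that of compound 3, although these compounds differ from compound 3 in more than this one place.

A moderate step towards a higher number in this assay is therefore expected. The expected change is a 3.3-fold higher number from compound 3 to compound 4 (0.52 log units; beyond the scatter), and this estimate is uncertain. Compound 4 is expected at 70000 nM, with an estimated range from 25000 nM to 200000 nM.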

Compound 4, half-maximal inhibitory concentration: > 100000 nM
Compound 4 gave a limit, no number (the forecaster's own chance of this, stated with the estimate: 15%); middle value at least 1.4-fold (0.15 log units) away from the limit.
By their numbers in this assay, from the lowest: compound 3; then compounds 1 and 2 (each within the scatter of the next). At a limit, above all of these: compound 4.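

In this assay, for the compounds shown here, ethoxy in place of (3-chlorophenyl)amino on a carbonyl carbon gives an at least 4.7-fold higher number from compound 3 to compound 4 (0.67 log units; beyond the scatter), which is the first direct reading of this place and shows that the change moves the number beyond the scatter. As far as these compounds go, compound 4 reads > 100000 nM, which is a limit of the assay and not a number, so the step gives only a floor for the change and its full size stays unknown. The other two steps are an at least 1.0-fold higher number from compound 2 to compound 4 (0.01 log units; that floor lies within the scatter) and an at least 1.7-fold higher number from compound 1 to compound 4 (0.24 log units; that floor lies within the scatter), and neither can be read as a change because their floors lie within the scatter and rest on this limit: the limit of > 100000 nM in this assay, at which 1 of the 4 values shown sits.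

The swap removes the aromatic ring and the amino nitrogen together, and the compounds shown leave open which of the two accounts for the step. An ethylamino group or a 3-chlorophenoxy group on the same carbonyl carbon would separate the ring from the nitrogen, and a phenylamino group would show what the chlorine contributes.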